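Hydrazone aryl swaps on a shared oxadiazole core: cytotoxicity

A few compounds are considered here, and "the series" means these few. Any claim that something is new, unique, unknown or untested is made for them only; others in the source may bear on it.

Measured compounds:
compound 1 `COc1ccccc1-c1nnc(-c2ccc(C(=O)N/N=C/c3cc(O)ccc3O)cc2)o1`: 100000 nM
compound 2 `COc1ccccc1-c1nnc(-c2ccc(C(=O)N/N=C/c3ccncc3)cc2)o1`: 173000 nM
compound 3 `COc1ccccc1-c1nnc(-c2ccc(C(=O)N/N=C/c3cccnc3)cc2)o1`: 167000 nM

In an ADME assay on THP-1 cells (Homo sapiens) for cytotoxicity (a lower number here means a stronger inhibitor, a higher number a weaker inhibitor), compound 3 gives 167000 nM, the second highest of the three numbers; its nearest neighbour is compound 2, and compound 1 lies furthest away. Neither gap reaches beyond the scatter: a 1.0-fold lower number from compound 2 to compound 3 (0.02 log units; within the scatter) and a 1.7-fold higher number from compound 1 to compound 3 (0.22 log units; within the scatter).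

Compound 4 `COc1ccccc1-c1nnc(-c2ccc(C(=O)N/N=C/c3c(O)cc(O)cc3O)cc2)o1` differs from compound 3 in one place: 2,4,6-trihydroxyphenyl in place of pyridin-3-yl on a carbon with a double bond to nitrogen. The step that bears most directly on it runs the other way, from a dihydroxyphenyl to a pyridyl, a 1.7-fold higher number from compound 1 to compound 3 (0.22 log units; within the scatter), and the parallel step a 1.7-fold higher number from compound 1 to compound 2 (0.24 log units; within the scatter) is of the same size; both are within the scatter. Among the compounds with values here, no measured pair shows the effect of adding a further hydroxy group, so the data offer no basis for a step beyond the scatter in this assay in either direction.

The number for compound 4 is therefore expected to sit near that of compound 1 and compound 3, with a step of a 1.5-fold lower number from compound 3 to compound 4 (0.18 log units; within the scatter) that is expected to fall inside the scatter. Compound 4 is estimated at 110000 nM, within 50000 nM to 250000 nM.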

Compound 4, half-maximal inhibitory concentration: 12400 nM
Estimate against measurement, compound 4: 8.9-fold (0.95 log units) above; the whole stated range lies above it.
By their numbers in this assay, from the lowest: compound 4; then compounds 1, 3 and 2 (each within the scatter of the next).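

In this assay, the three aryl groups seen earlier on the carbon with a double bond to nitrogen gave numbers within the scatter of one another, so this position looked insensitive to the change of group, but 2,4,6-trihydroxyphenyl ends that picture: against the two pyridyl compounds it gives a 13-fold lower number from compound 3 to compound 4 (1.13 log units; beyond the scatter) and a 14-fold lower number from compound 2 to compound 4 (1.14 log units; beyond the scatter), both large and beyond the scatter. Hydroxy groups on the ring are not enough on their own, for 2,5-dihydroxyphenyl in compound 1 stays within the scatter of both pyridyl compounds, while the step between the two hydroxylated rings is still beyond the scatter, though modest, at an 8.1-fold lower number from compound 1 to compound 4 (0.91 log units; beyond the scatter) and gives compound 4 the lowest number of the set. Nothing measured here bears on what lies behind these steps.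

The compounds shown leave open whether the lower number requires all the hydroxy groups of 2,4,6-trihydroxyphenyl or depends on how they are arranged, as a ring with a single hydroxy group is not among them. They also leave open what methoxy groups, an amine or a carboxylic acid would do on the same ring.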